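Swapping the aryl group on sulfur in a cinnamamide series

The source may hold more compounds than are shown below. What is called first, only, known or untested is meant among the compounds shown, and "the series" means these compounds.

Of the compounds shown here, two have been measured in a functional assay on HeLa cells (Homo sapiens) for inhibition, read by CCK-8 assay, with a stated time of 72 h, tested at 8 uM; a lower number here means less inhibition of growth, a higher number more inhibition of growth at the concentration tested. Compound 1, `COc1ccc(SCc2ccc(/C=C/C(=O)Nc3ccccc3N)cc2)cc1OC`, gives 21.9%, the lower of the two numbers seen so far. Compound 2, `Nc1ccccc1NC(=O)c1ccc(CSc2ccc(F)cc2)cc1`, gives 79.3% in this assay, a number well beyond the scatter above that of compound 1; the two differ in more than one place, so only their two values can be compared. Compound 3, `CC(C)(C)c1ccc(SCc2ccc(/C=C/C(=O)Nc3ccccc3N)cc2)cc1`, has not yet been measured. It differs from compound 1 by 4-(tert-butyl)phenyl in place of 3,4-dimethoxyphenyl on a sulfur. Among the compounds with values here, no measured pair shows what such a change does in this assay, so the size of the step is open. Compound 3 is estimated at 30%, within 10% to 60%. This expectation means a step of a number 8.1 percentage points higher from compound 1 to compound 3 (within the scatter), small and likely within the scatter, because compound 1 starts from 21.9% and nothing measured speaks for a large move in either direction.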

Compound 3, percent growth inhibition at one concentration: 9.8%
Compound 3: the middle estimate sits 20.2 percentage points above what was measured; measured number outside the range, below it.
By their numbers in this assay, from the lowest: compound 3; then compound 1; then compound 2.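

In this assay, within the data shown here, the aryl group on the sulfur proves to matter: 4-(tert-butyl)phenyl in place of 3,4-dimethoxyphenyl gives a number 12.1 percentage points lower from compound 1 to compound 3 (beyond the scatter), a modest step but the first reading of this position from a pair that differs in one place. The two groups have the same count of heavy atoms and each holds one six-membered aromatic ring, yet the leaving group has two hydrogen-bond acceptors and the entering group has none. Nothing available accounts for the step.

The pair does not separate the loss of the two oxygens from the arrival of the tert-butyl group. A plain phenyl or a single methoxy group on that ring would be needed to tell these two parts of the change apart.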